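Benzoyl for Ethynyl on the Thioether Chain

The source may hold more compounds than are shown below. What is called first, only, known or untested is meant among the compounds shown, and "the series" means these compounds.

Three compounds of one shared core were measured in a functional assay on PC-3M cells (Homo sapiens) for cytotoxicity, read by MTT assay, with a stated time of 48 h; on this read-out lower numbers stand for stronger inhibition and higher numbers for weaker inhibition. Compound 1 `Cc1nnc(SCc2ccccc2)n1N1C(=O)c2ccccc2C1=O` gives only a limit in this assay, > 200000 nM. Compound 2 `Cc1ccc(C(=O)CSc2nnc(C)n2N2C(=O)c3ccccc3C2=O)cc1` likewise gives only a limit, > 200000 nM. Compound 3 `C#CCSc1nnc(CC)n1N1C(=O)c2ccccc2C1=O` also stands at a limit in this assay, > 200000 nM, so its place among the three is not a number but the same boundary at which all three sit, (the limit of > 200000 nM in this assay, at which 3 of the 3 values shown sit). Among the measured compounds shown here, the one step between measured compounds that differ in a single place is a step that the two limits leave unreadable from compound 1 to compound 2, and its size cannot be read.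

Compound 4 `CCc1nnc(SCC(=O)c2ccccc2)n1N1C(=O)c2ccccc2C1=O` differs from compound 3 by benzoyl in place of ethynyl on a saturated chain carbon bound to a sulfur. For the measured compounds named here, no measured step bears on this change directly, and compound 2, which carries a related carbonyl group on the same saturated chain carbon bound to a sulfur, sits at the limit. Compound 4 is therefore expected to remain at the limit, with an estimated step that the limit leaves unreadable from compound 3 to compound 4. The estimate for compound 4 in this assay is 250000 nM, within 100000 nM to 700000 nM.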

Compound 4, half-maximal inhibitory concentration: > 200000 nM
Compound 4: no number, only a limit (the forecaster's own chance of this, stated with the estimate: 80%); the middle value is on the limit's open side.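

In this assay compound 4 gives only a limit, > 200000 nM, so the step from compound 3 to compound 4 cannot be read. All the values shown sit at one boundary: the limit of > 200000 nM in this assay, at which 4 of the 4 values shown sit. The compounds shown leave open whether any change on the saturated chain carbon bound to a sulfur yields a measurable number in this assay.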